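This account rests on a few compounds, and the source may have more. Where it says the series, first, only, none or still open, it means among the compounds named here.

Measured so far:
compound 1 `COc1ccc(/C=C/c2cc(OC)cc(OC)c2/C=C/C(=O)c2cc3ccccc3oc2=O)cc1` — 9170 nM
compound 2 `COc1ccc(/C=C/c2cc(OC)cc(OC)c2/C=C/C(=O)c2cc3cc(Cl)ccc3oc2=O)cc1` — > 60000 nM (a limit of the assay)

Going by the values given here, in an assay on isolated protein for inhibition of Amine oxidase [flavin-containing] B (Homo sapiens), read by fluorescence, with a stated time of 15 min (a higher number here means a weaker inhibitor, a lower number a stronger inhibitor), compound 1 gives 9170 nM, the only number in the set. Compound 2 reaches only a limit of the assay, (the limit of > 60000 nM in this assay, at which 1 of the 2 values shown sits). Compound 3 `COc1ccc(/C=C/c2cc(OC)cc(OC)c2/C=C/C(=O)c2cc3cc(F)ccc3oc2=O)cc1` differs from compound 1 by fluoro in place of hydrogen on an aromatic carbon. Among the compounds with values here, the one measured step that bears on this is an at least 6.5-fold higher number from compound 1 to compound 2 (0.81 log units; beyond the scatter), where chloro in place of hydrogen sits at the same aromatic carbon. A halogen there has so far weakened inhibition, so for fluoro in place of hydrogen a step in the same direction is expected, though whether of the same size or smaller cannot be read from one step. The estimate for compound 3 is therefore a weakening, a 2.2-fold higher number from compound 1 to compound 3 (0.34 log units; beyond the scatter). Compound 3 is expected at 20000 nM, between 7000 nM and 60000 nM.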

Compound 3, half-maximal inhibitory concentration: 10200 nM
The estimate for compound 3 lay 2.0-fold (0.29 log units) above the measured number; measured number inside the range.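

In this assay, fluoro in place of hydrogen on this aromatic carbon gives a 1.1-fold higher number from compound 1 to compound 3 (0.05 log units; within the scatter), so a halogen at this place does not in itself weaken inhibition in this series. The loss seen so far goes with chloro and not with halogen as such, with an at least 5.8-fold lower number from compound 2 to compound 3 (0.76 log units; beyond the scatter) for fluoro in place of chloro. On these data alone, compound 2 stands at a limit and not at a number, so the true size of its loss stays unknown: the limit of > 60000 nM in this assay, at which 1 of the 3 values shown sits.

With only fluoro and chloro shown on this carbon, it stays open whether bromo, an amine or a carboxylic acid there would track with fluoro or with chloro. As far as these compounds go, it also stays open whether fluoro on the other aromatic carbons of this ring would leave inhibition equally unmoved.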